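Swapping a propyl chain for a dimethylaminoethyl chain

This account rests on a few compounds, and the source may have more. Where it says the series, first, only, none or still open, it means among the compounds named here.

Measured in a functional assay on KB cells (Homo sapiens) for inhibition, with a stated time of 72 h; a higher number here means a weaker inhibitor, a lower number a stronger inhibitor:
Compound 1 `COc1cc(C(=O)c2cccc3[nH]ccc23)cc(OC)c1OC` gives 50.7 nM
Compound 2 `CCCn1ccc2cc(C(=O)c3cc(OC)c(OC)c(OC)c3)ccc21` gives 1900 nM

Compound 2 at 1900 nM has the higher of the two numbers, beyond the scatter from compound 1 in this assay and so the weaker inhibitor of the pair. Compound 3 `COc1cc(C(=O)c2ccc3c(ccn3CCN(C)C)c2)cc(OC)c1OC` differs from compound 2 by dimethylamino in place of methyl on a saturated chain carbon, two bonds along the chain from an aromatic nitrogen, which turns propyl into 2-(dimethylamino)ethyl. Among the compounds with values here, no measured pair shows this change, so only a small step toward a lower number is expected in this assay, likely within the scatter. The estimated change is a 1.3-fold lower number from compound 2 to compound 3 (0.10 log units; within the scatter) as a best guess. For compound 3 the expected value is 1500 nM, with an estimated range from 300 nM to 6000 nM.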

Compound 3, half-maximal inhibitory concentration: 5200 nM
For compound 3 the middle estimate is 3.5-fold (0.54 log units) below the measured one, and the stated range covers the measured number.
By their numbers in this assay, from the lowest: compound 1; then compound 2; then compound 3.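

In this assay, turning propyl into 2-(dimethylamino)ethyl gives a 2.7-fold higher number from compound 2 to compound 3 (0.44 log units; beyond the scatter) at this chain position, so the position responds to the change, and in the direction of a weaker inhibitor. This modest step rests on a single pair. No available evidence accounts for it. Still open, as far as these compounds go, is whether a longer chain carrying dimethylamino, or a carboxylic acid at the chain end, would move the number the same way. Also open, from the compounds shown here alone, is how a 2-(dimethylamino)ethyl chain would behave on the core of compound 1.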